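The source may report more compounds than this note shows. Statements on the series, on what has been measured and on what is new or still open speak of the compounds shown alone.

In an ADME assay on A549 cells (Homo sapiens) for inhibition, read by MTT assay, with a stated time of 48 h (a lower number here means a stronger inhibitor of growth, a higher number a weaker inhibitor of growth), compound 1 (`Cc1ccc(OCc2cn(Cc3cccc(Cl)c3)nn2)cc1`) gives > 100 ug/mL as a limit of the assay and not a number. Compound 2 (`Clc1ccc(Cn2cc(COc3ccc(Cl)cc3)nn2)cc1`) gives > 100 ug/mL as a limit of the assay too. Compound 2 therefore has no numeric value, and the only other result shown is also a limit (the limit of > 100 ug/mL in this assay, at which 2 of the 2 values shown sit). For the measured compounds named here, no step between measured compounds is available for sizing a change. Compound 3 (`Clc1ccc(OCc2cn(Cc3cccc(Cl)c3)nn2)cc1`) has the same atoms as compound 2, joined differently, with 3-chlorophenyl in place of 4-chlorophenyl on a saturated chain carbon bound to an aromatic nitrogen. In this assay no change beyond the scatter is expected in either direction, and another limit is the most likely report. The expected step is a step that the limit leaves unreadable from compound 2 to compound 3 by this estimate. For compound 3 the estimated value is 130 ug/mL with an expected range from 70 ug/mL to 300 ug/mL on this read-out.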

Compound 3, concentration for 50% growth inhibition: > 100 ug/mL
Compound 3 was reported as a limit (the forecaster's own chance of this, stated with the estimate: 80%); the middle value does not contradict the limit.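

In this assay compound 1, compound 2 and compound 3 all report limits and not numbers, and no step between them can be read: the limit of > 100 ug/mL in this assay, at which 3 of the 3 values shown sit.

The compounds shown leave open whether 3-chlorophenyl in place of 4-chlorophenyl, or chloro in place of methyl, changes the result in this assay at all.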